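Lengthening an iodoacetamide linker on an adenosine triphosphate probe

The source may report more compounds than this note shows. Statements on the series, on what has been measured and on what is new or still open speak of the compounds shown alone.

Compound 1 `CN(CCCN(C)C(=O)CCCCNc1ncnc2c1ncn2[C@@H]1O[C@H](COP(=O)(O)OP(=O)(O)OP(=O)(O)O)[C@@H](O)[C@H]1O)C(=O)CCCCNC(=O)CI` gives 0% in an assay on isolated protein for inhibition of hexokinase-3 (Rattus norvegicus), with a stated time of 6 h, tested at 10 mM; a higher number here means more inhibition at the concentration tested (going by the name of the read-out), a lower number less inhibition.
Compound 2 `O=C(CI)NCCCCCCCNc1ncnc2c1ncn2[C@@H]1O[C@H](COP(=O)(O)OP(=O)(O)OP(=O)(O)O)[C@@H](O)[C@H]1O` gives 20% in this assay.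
Compound 3 `O=C(CI)NCCNc1ncnc2c1ncn2[C@@H]1O[C@H](COP(=O)(O)OP(=O)(O)OP(=O)(O)O)[C@@H](O)[C@H]1O` gives 0% in this assay.

All three share the same triphosphate core and carry a reactive iodoacetamide at the end of a chain attached to the aromatic amine. Compound 2 stands highest of the three in this assay, and both compound 1 and compound 3 sit below it by more than the usual scatter. For the measured compounds named here, the one single-point step among them, a number 20 percentage points lower from compound 2 to compound 3 (beyond the scatter), shows that shortening the chain takes the signal away entirely.

Compound 4 `O=C(CI)NCCC(=O)NCCCCCCNc1ncnc2c1ncn2[C@@H]1O[C@H](COP(=O)(O)OP(=O)(O)OP(=O)(O)O)[C@@H](O)[C@H]1O` has not been measured. Compared with compound 2 it carries a group of 10 heavy atoms (5 carbon, 2 nitrogen, 2 oxygen, 1 iodine; no ring) in place of a group of 6 heavy atoms (3 carbon, 1 nitrogen, 1 oxygen, 1 iodine; no ring), on a saturated chain carbon, six bonds along the chain from a nitrogen on an aromatic ring. This lengthens the chain and adds an amide, moving in the direction of compound 1, whose long amide-containing linker gives 0%. Going by the values given here, no measured step matches this change exactly, so the expectation is uncertain. Because compound 1 gives 0% and compound 2 gives 20%, compound 4 is expected to lose some inhibition, with the estimated step of a number 12 percentage points lower from compound 2 to compound 4 (beyond the scatter) likely within or at the edge of the scatter. Compound 4 is estimated at 8%, in the range 0% to 25%.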

Compound 4, a percentage reported as inhibition, at one concentration (the size of the read-out at that concentration, not a potency): 0%
Estimate against measurement, compound 4: 8 percentage points above; the range from low to high includes it.
By their numbers in this assay, from the lowest: compounds 1, 3 and 4 (each within the scatter of the next); then compound 2.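

In this assay, placing a group of 10 heavy atoms, which includes 2 hydrogen-bond donors, where (((iodomethyl)carbonyl)amino)methyl stood on a saturated chain carbon, six bonds along the chain from a nitrogen on an aromatic ring, gives a number 20 percentage points lower from compound 2 to compound 4 (beyond the scatter). Earlier, only a shorter chain had been seen to cost inhibition, in the step of a number 20 percentage points lower from compound 2 to compound 3 (beyond the scatter); this result shows that a larger group on the chain can cost the same amount, so among these single changes, neither one keeps the signal of compound 2. None of the available evidence explains this loss.

The larger group in compound 4 differs from the group it replaces in both chain length and its added amide, so these compounds leave open which of the two matters. A longer plain carbon chain without the added amide would help to separate the two, while a chain of intermediate length between those of compound 3 and compound 2 would show whether the number in this assay stays level with that of compound 2 or is lower.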